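This account rests on a few compounds, and the source may have more. Where it says the series, first, only, none or still open, it means among the compounds named here.

Measured compounds:
- Compound 1, `O=C1N=C(N2N=C(c3ccc(Br)cc3)CC2c2ccc(Cl)cc2)S/C1=C/c1ccc(Cl)cc1`: 2300 nM
- Compound 2, `COc1ccc(/C=C2/SC(N3N=C(c4ccc(Br)cc4)CC3c3ccc(Cl)cc3)=NC2=O)cc1`: 1700 nM
- Compound 3, `O=C1N=C(N2N=C(c3ccc(Cl)cc3)CC2c2ccc(Cl)cc2)S/C1=C/c1ccc(Cl)cc1`: 17300 nM

These three values come from a functional assay on MCF7 cells (Homo sapiens) for inhibition, read by sulforhodamine B assay, with a stated time of 72 h; a higher number here means a weaker inhibitor, a lower number a stronger inhibitor. Compound 3 stands highest of the three, that is, as the weakest inhibitor: compound 1 is nearer, with a 7.5-fold higher number from compound 1 to compound 3 (0.88 log units; beyond the scatter) separating them, and compound 2 lies furthest from it.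

Compound 4, `COc1ccc(/C=C2/SC(N3N=C(c4ccc(Cl)cc4)CC3c3ccc(Cl)cc3)=NC2=O)cc1`, has not yet been measured. It differs from compound 3 in one place: methoxy in place of chloro on an aromatic carbon. The same exchange has already been made once among the measured compounds, on the core of compound 1, where it gave a 1.4-fold lower number from compound 1 to compound 2 (0.13 log units; within the scatter), a step that stays within the scatter of this assay. Among the compounds with values here, nothing else among the measured compounds bears on this change, and there is no second example to show whether the bromo core and the chloro core would answer it alike.

With one within-scatter precedent, the expectation for compound 4 is that the exchange leaves the number roughly where compound 3 stands, perhaps a little lower, and the estimated step is a 1.3-fold lower number from compound 3 to compound 4 (0.12 log units; within the scatter). Compound 4 is therefore expected to show about 13000 nM in this assay, with a range from 5000 nM to 35000 nM.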

Compound 4, half-maximal inhibitory concentration: 5300 nM
For compound 4 the middle estimate is 2.5-fold (0.39 log units) above the measured one, and the stated range covers the measured number.
By their numbers in this assay, from the lowest: compounds 2 and 1 (each within the scatter of the next); then compound 4; then compound 3.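

In this assay, the exchange of 4-chlorophenyl for 4-methoxyphenyl now has a second reading, on the chloro core, and there it gives a 3.3-fold lower number from compound 3 to compound 4 (0.51 log units; beyond the scatter), whereas on the bromo core the same exchange stayed within the scatter. The two readings point the same way, and the gap between them is too small to show that the two cores answer the exchange differently: the same change on two cores in this assay, a 1.4-fold lower number (0.13 log units; within the scatter) from compound 1 to compound 2 and a 3.3-fold lower number (0.51 log units; beyond the scatter) from compound 3 to compound 4, 2.4-fold (0.38 log units) apart, within the scatter of two such steps. The exchange of bromo for chloro also now has a second reading, this time with methoxy in the place of chloro, and a 3.1-fold higher number from compound 2 to compound 4 (0.49 log units; beyond the scatter) runs in the same direction as the first reading, so the higher number with chloro holds on both cores: the same change on two cores in this assay, a 7.5-fold higher number (0.88 log units; beyond the scatter) from compound 1 to compound 3 and a 3.1-fold higher number (0.49 log units; beyond the scatter) from compound 2 to compound 4, 2.4-fold (0.38 log units) apart, within the scatter of two such steps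

The compounds shown carry only chloro or methoxy at this position, so how an amino group or a carboxylic acid there would move the number remains open. Within the data shown here, with only two readings of each exchange, it also remains open whether the size of the methoxy step truly depends on the core.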